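Fluoro for Ethoxy on a Weakly Cytotoxic Thiourea

A few compounds are considered here, and "the series" means these few. Any claim that something is new, unique, unknown or untested is made for them only; others in the source may bear on it.

Three measured compounds and one unmeasured one make up the set. In a functional assay on U-937 cells (Homo sapiens) for cytotoxicity, read by MTT assay, with a stated time of 48 h (a lower number here means a stronger inhibitor, a higher number a weaker inhibitor), compound 1 `Clc1cccc2sc(Nc3nc4ccccc4s3)nc12` reaches only a limit, > 50000 nM. Compound 2 `Fc1ccc2nc(Nc3nc4ccccc4s3)sc2c1` gives 40600 nM; 43500 nM (2 entries) in this assay, and its repeat entries sit close together, as the several entries of compound 2 in this assay, 40600 nM; 43500 nM (2 entries) shows. Going by the values given here, compound 3 `CCOc1ccc2nc(NC(=S)Nc3ccccc3)sc2c1` gives 37700 nM in this assay; it is the only single number among the three, and the values of compound 2 lie within the scatter of it, so no order between those two can be claimed. Compound 4 `Fc1ccc2nc(NC(=S)Nc3ccccc3)sc2c1` differs from compound 3 by fluoro in place of ethoxy on an aromatic carbon. Among the compounds with values here, no step between two measured compounds is available to guide this change. Compound 2 already carries the fluoro group on the shared core and sits near the top of the tested range, so the move is expected to stay within the scatter or drift slightly weaker. The change is estimated at a 1.2-fold higher number from compound 3 to compound 4 (0.08 log units; within the scatter). Compound 4 is expected to give 45000 nM, with a range from 20000 nM to 100000 nM, and a fair chance that only a limit is reported.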

Compound 4, half-maximal inhibitory concentration: > 50000 nM
Compound 4 ended at the assay's limit; the forecaster's own chance of this, stated with the estimate: 40%; middle value at least 1.1-fold (0.04 log units) away from the limit.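

In this assay, fluoro in place of ethoxy on this aromatic carbon gives the set its first readable step, an at least 1.3-fold higher number from compound 3 to compound 4 (0.12 log units; that floor lies within the scatter), and that step shows no lower number with the smaller group. Compound 4 gives > 50000 nM, which is a limit of the assay and not a number. The step therefore stands only as a floor, and its true size cannot be read, because the assay's read-out ends where compound 4 sits: the limit of > 50000 nM in this assay, at which 2 of the 4 values shown sit.

The compounds shown leave open whether any group at this place can bring the number clearly down, for example an amine, a carboxylic acid or a chain longer than ethoxy. They also leave open how far compound 4 really lies from compound 3.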